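Adding a Second Hydroxy Group to Compound 3

A few compounds are considered here, and "the series" means these few. Any claim that something is new, unique, unknown or untested is made for them only; others in the source may bear on it.

Of the compounds shown here, three have been measured in an assay on isolated protein for inhibition of Alpha glucosidase (Homo sapiens), with stated times of 5 min and 15 min, tested at 50 uM; a higher number here means more inhibition at the concentration tested (going by the name of the read-out), a lower number less inhibition. Compound 1 `O=C(/C=C(O)/C=C/c1cccc(O)c1)c1cc(Cl)ccc1O` gives 62.4%, the highest of the three numbers. Compound 2 `Cc1cccc(/C=C2\CCC/C(=C\c3ccccc3)C2=O)c1`, built on a different core, gives 47.9%. Compound 3 `O=C(/C=C(O)/C=C/c1cccc(O)c1)c1ccccc1O` gives 40.4%, the lowest of the three; its gap to compound 2 lies within the scatter, while its gap to compound 1 lies beyond it. Among the measured compounds shown here, the one step measured between compounds differing in a single place runs a number 22 percentage points lower from compound 1 to compound 3 (beyond the scatter), for hydrogen in place of chloro on an aromatic carbon of the ring that carries the ketone.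

Compound 4 `O=C(/C=C(O)/C=C/c1ccc(O)c(O)c1)c1ccccc1O` is not yet measured. It differs from compound 3 by hydroxy in place of hydrogen on an aromatic carbon, on the other aromatic ring, ortho to a hydroxy group and para to a large group. For the measured compounds named here, no measured step concerns a hydroxy entering, and the only step in hand touches a different ring with a different group, so the data give no direction for this change. Compound 4 is therefore expected to come out close to compound 3, with a step of a number 5.6 percentage points higher from compound 3 to compound 4 (within the scatter) that is estimated to stay within the scatter. The estimate for compound 4 in this assay is 46%, ranging from 25% to 68%.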

Compound 4, a percentage reported as inhibition, at one concentration (the size of the read-out at that concentration, not a potency): 93.6%
For compound 4 the middle estimate is 47.6 percentage points below the measured one; measured number above the stated range.
By their numbers in this assay, from the lowest: compounds 3 and 2 (each within the scatter of the next); then compound 1; then compound 4.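

In this assay the number runs a number 53.2 percentage points higher from compound 3 to compound 4 (beyond the scatter), so this position, ortho to a hydroxy group and para to a large group, responds strongly to hydroxy in place of hydrogen. Among the compounds shown here, the only earlier step, a number 22 percentage points lower from compound 1 to compound 3 (beyond the scatter), is a modest one that concerns chloro on a different ring, so it said nothing about this ring; compound 4 now shows that a change here can count for more than that one did. No measurement at hand accounts for the size of this step.

As far as these compounds go, it remains open whether hydroxy itself is needed on this aromatic carbon, or whether a methoxy group, an amine or a fluorine atom in the same place would give a similar number. Also open, from the compounds shown here alone, is whether the chloro of compound 1 and the added hydroxy of compound 4 would add up in one molecule, and how the step would look as a potency, since this read-out gives the size of the inhibition at one concentration only.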